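This account rests on a few compounds, and the source may have more. Where it says the series, first, only, none or still open, it means among the compounds named here.

Compound 1, `Nc1cc(N)c2nc(-c3ccccc3)c(Oc3ccc(F)cc3)nc2c1`: 64600 nM
Compound 2, `Nc1cc(N)c2nc(-c3ccccc3)c(Sc3ccc(Cl)c(Cl)c3)nc2c1`: 53700 nM

Of the compounds shown here, two sharing one core have been measured in a functional assay on TK-10 cells (Homo sapiens) for inhibition, read by sulforhodamine B assay, with a stated time of 48 h; on this read-out lower numbers stand for higher toxicity in this test and higher numbers for lower toxicity in this test. Compound 1 gives 64600 nM, and compound 2 gives 53700 nM. For the measured compounds named here, the single step between them, a 1.2-fold lower number from compound 1 to compound 2 (0.08 log units; within the scatter), means the two numbers cannot be told apart; compound 2 stands alongside compound 1 rather than apart from it.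

Compound 3, `Nc1cc(N)c2nc(-c3ccccc3)c(NCc3ccc(F)cc3)nc2c1`, has not been measured. It differs from compound 2 at the same place that was changed between compound 1 and compound 2: (4-fluorobenzyl)amino in place of (3,4-dichlorophenyl)sulfanyl on an aromatic carbon. Going by the values given here, the only step that bears on this position is the one from compound 1 to compound 2, and it stayed within the scatter when the whole group at this position was exchanged. With nothing in the data showing that this position moves the read-out, the step into compound 3 is expected to stay within the scatter as well, so a 1.0-fold higher number from compound 2 to compound 3 (0.01 log units; within the scatter) is the estimate for compound 3. Compound 3 is therefore estimated to give 55000 nM in this assay , with a range from 20000 nM to 150000 nM.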

Compound 3, concentration lethal to 50% of the cells: 53700 nM
For compound 3 the middle estimate is 1.0-fold (0.01 log units) above the measured one; low and high end bracket the measured number.
By their numbers in this assay, from the lowest: compounds 2, 3 and 1 (each within the scatter of the next).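

In this assay, putting (4-fluorobenzyl)amino on this aromatic carbon gives no change at the digits printed from compound 2 to compound 3 (within the scatter), and measured against the 4-fluorophenoxy group it gives a 1.2-fold lower number from compound 1 to compound 3 (0.08 log units; within the scatter). The position now holds three groups joined to the shared core through oxygen, sulfur and nitrogen, and the numbers of all three compounds lie within the scatter of one another, even though (4-fluorobenzyl)amino brings a hydrogen-bond donor that (3,4-dichlorophenyl)sulfanyl does not have. No evidence is available that would account for this level picture across the three groups.

On these data alone, all three groups carry a six-membered aromatic ring of carbon only, so it remains open whether a group without such a ring at this position, such as a plain amine, a carboxylic acid or a longer alkyl chain, would give a number outside this narrow set. The compounds also leave open whether the read-out responds to any other part of the molecule, since the phenyl group and the two amino groups on the core are the same in all three.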